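Chain Length Between Core and Phenyl in Pannexin-1 Inhibition

A few compounds are considered here, and "the series" means these few. Any claim that something is new, unique, unknown or untested is made for them only; others in the source may bear on it.

Compound 1 `O=C(O)c1cn(Cc2ccccc2)c2ccc([N+](=O)[O-])cc12` and compound 3 `O=C(O)c1cn(CCCc2ccccc2)c2ccc([N+](=O)[O-])cc12` share one core and differ only by phenethyl in place of phenyl on a saturated chain carbon bound to an aromatic nitrogen. In an assay on cells (Oocyte) for inhibition of pannexin-1 (Mus musculus), read by voltage clamp, tested at 50 uM, in the presence of a further agent that is not named here (on this read-out higher numbers stand for more inhibition at the one concentration tested (going by the name of the read-out) and lower numbers for less inhibition), compound 1 gives 65%, and compound 3 gives 71%, so the step of a number 6 percentage points higher from compound 1 to compound 3 (within the scatter) is small. Compound 2 `O=C(O)c1cc2cc([N+](=O)[O-])ccc2n1CCCc1ccccc1` is built on a different core; how the two cores differ is not broken down here. In this assay compound 2 gives 65.5%. Compound 4 `O=C(O)c1cc2cc([N+](=O)[O-])ccc2n1CCCCCc1ccccc1` is not yet measured and differs from compound 2 by phenethyl in place of phenyl on a saturated chain carbon, three bonds along the chain from an aromatic nitrogen. The place of the change in compound 4 is three bonds along the chain from the aromatic nitrogen rather than bound to it. This is the same kind of change as from compound 1 to compound 3, not the same change. The step is expected to be a number 4.5 percentage points higher from compound 2 to compound 4 (within the scatter), resting on compound 1 and compound 3 with a number 6 percentage points higher from compound 1 to compound 3 (within the scatter). Compound 4 is therefore estimated at 70%, between 58% and 80%.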

Compound 4, a percentage reported as inhibition, at one concentration (the size of the read-out at that concentration, not a potency): 58%
The estimate for compound 4 lay 12 percentage points above the measured number; measured number inside the range.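

Phenethyl in place of phenyl gives, in this assay, a number 7.5 percentage points lower from compound 2 to compound 4 (within the scatter). Set beside the earlier step on the other core, this shows no difference between the two cores that stands out from the usual scatter: the same change on two cores in this assay, a number 6 percentage points higher (within the scatter) from compound 1 to compound 3 and a number 7.5 percentage points lower (within the scatter) from compound 2 to compound 4, 13.5 percentage points apart, within the scatter of two such steps. Within the data shown here, it does not show that the change has a real effect on either core, or that it would have the same effect on both, as each core offers only one pair and both steps lie within the scatter.

All the compounds shown carry a carboxylic acid, a nitro group and an unsubstituted phenyl. From the compounds shown here alone, it remains open how an amide in place of the acid, an amine in place of the nitro group or a longer chain would read in this assay.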